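Halogen swap on the anilide ring in a pyrazole amide series

The source may report more compounds than this note shows. Statements on the series, on what has been measured and on what is new or still open speak of the compounds shown alone.

Measured so far, in a functional assay on MCF7 cells (Homo sapiens) for cytotoxicity, read by MTT assay, with a stated time of 48 h; a higher number here means a weaker inhibitor, a lower number a stronger inhibitor:
compound 1 `O=C(Nc1ccc(Br)cc1)c1cn(-c2ccccc2)nc1-c1ccccc1`, 5750 nM
compound 2 `O=C(Nc1ccccc1)c1cn(-c2ccccc2)nc1-c1ccc(Cl)cc1`, 2340 nM
compound 3 `O=C(Nc1ccc(Cl)cc1)c1cn(-c2ccccc2)nc1-c1ccc(Cl)cc1`, 3750 nM

Compound 3 sits second of the three numbers in this assay, though all three lie within the scatter of one another: compound 1 gives 5750 nM and compound 2 gives 2340 nM, and neither gap to compound 3 is beyond the scatter.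

Compound 4 is `O=C(Nc1ccc(Br)cc1)c1cn(-c2ccccc2)nc1-c1ccc(Cl)cc1`. Its difference from compound 3 is bromo in place of chloro on an aromatic carbon, para to a large group, on the (4-chlorophenyl)amino side.

Going by the values given here, only one step among the measured compounds touches this position: a 1.6-fold higher number from compound 2 to compound 3 (0.20 log units; within the scatter), a change within the scatter. Among the compounds with values here, no measured pair isolates a chloro-to-bromo exchange; compound 1 and compound 3 differ in two places at once, so their values tell nothing clean about this swap. Within the data shown here, with the one neighbouring step being flat, no step beyond the scatter is expected in this assay.

Compound 4 is therefore estimated at 4000 nM, with a range of 2000 nM to 8500 nM, which means an expected step of a 1.1-fold higher number from compound 3 to compound 4 (0.03 log units; within the scatter).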

Compound 4, half-maximal inhibitory concentration: 5310 nM
Beside the measured number, compound 4's estimate is 1.3-fold (0.12 log units) below it; measured number inside the range.
By their numbers in this assay, from the lowest: compounds 2, 3, 4 and 1 (each within the scatter of the next, the first and the last beyond it).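

In this assay, the swap from 4-chlorophenyl to 4-bromophenyl can now be read directly, and it gives a 1.4-fold higher number from compound 3 to compound 4 (0.15 log units; within the scatter), so the two halogens are not separated at this position on the shared core. Bromo in place of hydrogen gives a 2.3-fold higher number from compound 2 to compound 4 (0.36 log units; beyond the scatter), the only step beyond the scatter in this set, but it is a modest one and offers no ground for ranking bromo over chloro, given the step between those two halogens. Chloro in place of hydrogen gives a 1.1-fold lower number from compound 1 to compound 4 (0.03 log units; within the scatter), and this change reads alike on the two cores: the same change on two cores in this assay, a 1.6-fold higher number (0.20 log units; within the scatter) from compound 2 to compound 3 and a 1.1-fold lower number (0.03 log units; within the scatter) from compound 1 to compound 4, 1.7-fold (0.24 log units) apart, within the scatter of two such steps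

The compounds shown carry only hydrogen, chloro or bromo on the anilide ring, so it remains open whether a methoxy group, an amine or a carboxylic acid at this position would give a step clearly beyond the scatter. Also open, from the compounds shown here alone, is whether the modest step from hydrogen to bromo would hold on a core without the chloro group.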